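The source may report more compounds than this note shows. Statements on the series, on what has been measured and on what is new or still open speak of the compounds shown alone.

In a physicochemical assay for solubility (on this read-out higher numbers stand for higher solubility and lower numbers for lower solubility), three compounds sharing one core have been measured. Compound 1 `CNC(=O)c1cc(C(=O)NC2CC2)cn(Cc2ccc(OC)cc2)c1=O` reports >= 143 ug/mL, which is a limit of the assay and not a number. Compound 2 `CNC(=O)c1cc(C(=O)NC2CC2)cn(Cc2cccc3[nH]ccc23)c1=O` gives 78 ug/mL. Compound 3 `CNC(=O)c1cc(C(=O)NC2CC2)cn(Cc2cccc3cn[nH]c23)c1=O` reports >= 181 ug/mL, which is likewise only a limit.

Compound 4 `CNC(=O)c1cc(C(=O)NC2CC2)cn(Cc2cccc(C#N)c2)c1=O` carries 3-cyanophenyl in place of 1H-indazol-7-yl on a saturated chain carbon bound to an aromatic nitrogen, and the count of the change reads (3-cyanophenyl in place of 1H-indazol-7-yl on a saturated chain carbon bound to an aromatic nitrogen).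

All three measured steps fall at this same place. The clearest is an at least 2.3-fold higher number from compound 2 to compound 3 (0.36 log units; beyond the scatter), while the other side of the series shows an at least 1.8-fold lower number from compound 1 to compound 2 (0.26 log units; that floor lies within the scatter). The remaining comparison is a step that the two limits leave unreadable from compound 1 to compound 3, so it offers no size to carry over. None of these steps installs 3-cyanophenyl, so they give no direct measure of the new group.

No step beyond the scatter is therefore expected in this assay, and the estimated change is an at least 1.2-fold lower number from compound 3 to compound 4 (0.11 log units; that floor lies within the scatter). For compound 4 the expected value is 140 ug/mL, with an estimated range of 60 ug/mL to 220 ug/mL.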

Compound 4, solubility: >= 148 ug/mL
Compound 4: only a limit was reported; the forecaster's own chance of this, stated with the estimate: 50%; middle value at least 1.0-fold (0.02 log units) away from the limit.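

In this assay compound 4 reports >= 148 ug/mL, which is a limit of the assay and not a number, so 3-cyanophenyl, with 0 hydrogen-bond donors, also gives only a limit at this place, as 1H-indazol-7-yl with its 1 donor does. Among the compounds shown here, the one readable new comparison is an at least 1.8-fold higher number from compound 2 to compound 4 (0.27 log units; that floor lies within the scatter), so this change from 1H-indol-4-yl cannot be separated from the usual scatter of the assay. The steps from compound 3 and from compound 1 to compound 4 cannot be read, as each joins two limits.

As far as these compounds go, the order among compound 1, compound 3 and compound 4 in this assay therefore remains open. Also open, from the compounds shown here alone, is how a group carrying an amine or a carboxylic acid would read on this saturated chain carbon bound to an aromatic nitrogen.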